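This account rests on a few compounds, and the source may have more. Where it says the series, first, only, none or still open, it means among the compounds named here.

Within the data shown here, in an ADME assay on microsomes from liver (Homo sapiens) for metabolic stability (a lower number here means that the compound disappears faster, a higher number that the compound lasts longer), compound 2 `CC(C)[C@H](C[C@H]1SC(=O)NC1=O)c1ccc(-c2ccc3cccc(F)c3c2)[nH]c1=O` gives 0.67 h, the lowest of the three numbers so far. Compound 1 `CC(C)[C@H](C[C@H]1OC(=O)NC1=O)c1ccc(-c2ccc3cccc(F)c3c2)[nH]c1=O` gives 1.68 h and compound 3 `CC(C)[C@H](C[C@@H]1OC(=O)NC1=O)c1ccc(-c2ccc3cccc(F)c3c2)[nH]c1=O` gives 2.07 h. Next is compound 4 `CC(C)[C@@H](C[C@H]1SC(=O)NC1=O)c1ccc(-c2ccc3cccc(F)c3c2)[nH]c1=O`: the two compounds have the same atoms and bonds and differ only in configuration as drawn: 1 of 2 stereo elements differ; a stereocentre at a saturated chain carbon is drawn S in compound 2 and R in compound 4. Among the measured compounds shown here, the only measured step that changes configuration alone is a 1.2-fold higher number from compound 1 to compound 3 (0.09 log units; within the scatter), and it concerns a saturated ring carbon, not the saturated chain carbon. The other two steps, a 2.5-fold lower number from compound 1 to compound 2 (0.40 log units; beyond the scatter) and a 3.1-fold higher number from compound 2 to compound 3 (0.49 log units; beyond the scatter), change atoms and bear less on this comparison. No step beyond the scatter is expected in this assay, although inversion at the chain carbon remains unmeasured. The expected result is a 1.2-fold higher number from compound 2 to compound 4 (0.08 log units; within the scatter). Compound 4 is estimated at 0.8 h, with an expected range of 0.35 h to 1.7 h.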

Compound 4, half-life: 1.24 h
Compound 4: middle estimate off by 1.6-fold (0.19 log units), on the low side, and the stated range covers the measured number.
By their numbers in this assay, from the lowest: compounds 2, 4, 1 and 3 (each within the scatter of the next, the first and the last beyond it).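

In this assay, inversion at the saturated chain carbon gives a 1.9-fold higher number from compound 2 to compound 4 (0.27 log units; within the scatter), the only reading at this stereocentre among the compounds shown. Together with a 1.2-fold higher number from compound 1 to compound 3 (0.09 log units; within the scatter) at the saturated ring carbon, it leaves both configuration-only steps within the scatter, so neither stereocentre shows a change that can be told from repeat variation. The new step reads on configuration alone: the fact that compounds 2 and 4 differ only in the configuration as drawn

As far as these compounds go, whether inversion at the chain carbon stays within the scatter with 2,4-dioxo-1,3-oxazolidin-5-yl remains open. Also open, from the compounds shown here alone, is how a carboxylic acid in place of the ring would read in this assay.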